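The compounds below may be only part of what the source reports. "The series", "measured", "known", "first", "only" and "open" are said of these compounds alone.

Of the compounds shown here, two have numbers so far. In a functional assay on HeLa cells (Homo sapiens) for inhibition, read by MTT assay, with a stated time of 72 h (a higher number here means a weaker inhibitor of growth, a lower number a stronger inhibitor of growth), compound 1 (`O=C1CC(N2C(=O)/C(=C/C(Cl)=C/c3ccc([N+](=O)[O-])cc3)SC2=S)C(=O)N1c1ccc(O)cc1`) gives 6130 nM and compound 2 (`C=CCOc1ccccc1/C=C1\SC(=S)N(C2CC(=O)N(c3ccc(Cl)cc3)C2=O)C1=O`) gives 47500 nM as its reading. Compound 2 holds the higher of the two numbers, a gap beyond the scatter, and is the weaker growth inhibitor of the pair. Compound 3 (`C=CCOc1cccc(/C=C2\SC(=S)N(C3CC(=O)N(c4ccc(Cl)cc4)C3=O)C2=O)c1`) has no number yet. It keeps the atoms of compound 2 but joins them differently (3-(allyloxy)phenyl in place of 2-(allyloxy)phenyl on a double-bonded chain carbon bound to a double-bonded ring carbon). The change is 3-(allyloxy)phenyl in place of 2-(allyloxy)phenyl on a double-bonded chain carbon bound to a double-bonded ring carbon. Going by the values given here, the two measured compounds differ in more than one place, and no measured step shows what this exchange does. The gap to compound 1 therefore gives no guide here. With nothing to size the change, no step beyond the scatter is expected in this assay for this exchange. The estimated 1.4-fold lower number from compound 2 to compound 3 (0.13 log units; within the scatter) stays within the scatter. Compound 3 is expected at 35000 nM with an estimated range (12000 nM to 100000 nM).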

Compound 3, concentration for 50% growth inhibition: > 100000 nM
Compound 3 ended at the assay's limit (the forecaster's own chance of this, stated with the estimate: 10%); middle value at least 2.8-fold (0.45 log units) away from the limit.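

In this assay, exchanging 2-(allyloxy)phenyl for 3-(allyloxy)phenyl on a double-bonded chain carbon bound to a double-bonded ring carbon gives an at least 2.1-fold higher number from compound 2 to compound 3 (0.32 log units; beyond the scatter). Going by these compounds alone, with the atoms unchanged and only their joining altered, this is the first measured sign that growth inhibition responds to where the allyloxy group sits on this phenyl ring, and the 2-(allyloxy)phenyl compound is the better of this pair. Compound 3 reads > 100000 nM, which is a limit of the assay and not a number, so the step gives only a lower bound on the size of the change: the limit of > 100000 nM in this assay, at which 1 of the 3 values shown sits.

On these data alone, whether a methoxy group, a longer ether chain, an amine or a carboxylic acid in place of the allyloxy group would keep or lose growth inhibition remains open, and this single pair cannot show whether the same sensitivity holds with other groups on the phenyl ring. Compound 1 differs from both compounds in more than one place, so it does not help to settle either question.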